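The source may report more compounds than this note shows. Statements on the series, on what has been measured and on what is new or still open speak of the compounds shown alone.

Compound 1 `COc1cc(-n2ncnc2-c2ccc(Cl)c(Cl)c2)cc(OC)c1OC`: > 10000 nM (a limit)
Compound 2 `COc1cc(-n2ncnc2-c2cccc(Cl)c2)cc(OC)c1OC`: > 10000 nM (a limit)

Both compounds were tested in a functional assay on A549 cells (Homo sapiens) for antiproliferative activity, read by MTT assay, with a stated time of 72 h; on this read-out lower numbers stand for stronger inhibition and higher numbers for weaker inhibition. Compound 1 gives > 10000 nM, which is a limit of the assay and not a number. Compound 2 gives > 10000 nM, likewise a limit. Compound 2 therefore stands at the limit of > 10000 nM in this assay, at which 2 of the 2 values shown sit, with no numerical value to start from.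

Compound 3 `COc1cc(-n2ncnc2-c2ccc(SC)cc2)cc(OC)c1OC` differs from compound 2 by one change, 4-(methylsulfanyl)phenyl in place of 3-chlorophenyl on an aromatic carbon. Among the measured compounds shown here, only one measured step is available, a step that the two limits leave unreadable from compound 1 to compound 2. It concerns hydrogen in place of chloro, a different change, and it has no readable size, so it offers no measure to carry over. Any readable step in this assay could only run towards stronger inhibition, but the data do not show that one will occur. Compound 3 may well remain at a limit. The expected change is small and uncertain, estimated as an at least 1.2-fold lower number from compound 2 to compound 3 (0.09 log units; that floor lies within the scatter). For compound 3 the estimated value is 8000 nM, with an expected range of 300 nM to 30000 nM.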

Compound 3, half-maximal inhibitory concentration: 800 nM
Estimate against measurement, compound 3: 10-fold (1.00 log units) above; low and high end bracket the measured number.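

In this assay, putting 4-(methylsulfanyl)phenyl in place of 3-chlorophenyl on the aromatic carbon between two ring nitrogen atoms gives an at least 12-fold lower number from compound 2 to compound 3 (1.09 log units; beyond the scatter). On these data alone, putting the same group in place of 3,4-dichlorophenyl on that carbon gives an at least 12-fold lower number from compound 1 to compound 3 (1.09 log units; beyond the scatter), so both readable steps run towards stronger inhibition and are large, although their true size stays open, since each starts from a limit and not a number. This shows that the group on this carbon can bring the shared core off the limit, which the two chlorinated compounds could not show, as compound 3 alone carries a number while the others remain at the limit: the limit of > 10000 nM in this assay, at which 2 of the 3 values shown sit.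

The step from compound 2 to compound 3 changes both the substituent and its place on the phenyl ring, so the compounds shown cannot tell whether the sulfur-bearing group itself or its place accounts for the gain. As far as these compounds go, how a 4-chlorophenyl, a 4-methoxyphenyl or a 4-(ethylsulfanyl)phenyl group would fare on this same carbon remains open, and with it whether the gain is particular to the methylsulfanyl group.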